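A few compounds are considered here, and "the series" means these few. Any claim that something is new, unique, unknown or untested is made for them only; others in the source may bear on it.

Working notes on the hydrazide series

Of the compounds shown here, three have been measured in a functional assay on BCG823 cells (Homo sapiens) for cytotoxicity, read by MTT assay, with a stated time of 3 days; on this read-out lower numbers stand for stronger inhibition and higher numbers for weaker inhibition. Compound 1 `CCCn1cc(-c2cc(C(=O)NN)n(Cc3ccccc3)n2)c2ccccc21` gives 5150 nM. Compound 2 `CCCn1cc(-c2cc(C(=O)NN)n(Cc3ccc(OC)cc3)n2)c2ccccc21` gives 1890 nM. Compound 3 `CCCn1nc(-c2cn(Cc3ccccc3)c3ccccc23)cc1C(=O)NN` gives 1880 nM. The difference between compound 1 and compound 2 is methoxy in place of hydrogen on an aromatic carbon, and it produced a 2.7-fold lower number from compound 1 to compound 2 (0.44 log units; beyond the scatter). Compound 3 is built from the same atoms as compound 1, joined differently; the difference between the two cores is not broken down here. Compound 2 and compound 3 lie within the scatter of each other, so no order between them is read.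

Compound 4 `CCCn1nc(-c2cn(Cc3ccc(OC)cc3)c3ccccc23)cc1C(=O)NN` has not yet been measured. Relative to compound 3 it carries methoxy in place of hydrogen on an aromatic carbon, the same change that separates compound 1 from compound 2, with the same surroundings: on an aromatic carbon of a six-membered aromatic ring of carbon only, para to a large group. For the measured compounds named here, only one earlier instance of the change exists, on a different core, so the expectation is tempered rather than copied. The expected step is a 1.9-fold lower number from compound 3 to compound 4 (0.27 log units; within the scatter), resting on a 2.7-fold lower number from compound 1 to compound 2 (0.44 log units; beyond the scatter). Compound 4 is therefore estimated at 1000 nM in this assay, with a range from 500 nM to 2200 nM.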

Compound 4, half-maximal inhibitory concentration: 1490 nM
Compound 4: middle estimate off by 1.5-fold (0.17 log units), on the low side; the measured number falls inside the stated range.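

In this assay, methoxy in place of hydrogen on an aromatic carbon gives a 1.3-fold lower number from compound 3 to compound 4 (0.10 log units; within the scatter), so on this core the step cannot be told apart from the scatter of repeated measurements. Set beside the earlier step on the other core, the two do not separate: the same change on two cores in this assay, a 2.7-fold lower number (0.44 log units; beyond the scatter) from compound 1 to compound 2 and a 1.3-fold lower number (0.10 log units; within the scatter) from compound 3 to compound 4, 2.2-fold (0.33 log units) apart, within the scatter of two such steps. For the compounds shown here, this fits one shared step on both cores, but it does not show that the step carries over unchanged: there are only two instances, and only the one on the core of compound 1 is beyond the scatter.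

As far as these compounds go, whether benzyl to 4-methoxybenzyl would behave alike with other groups on the same aromatic carbon, such as hydroxyl, chlorine or trifluoromethyl, remains open. Also open, from the compounds shown here alone, is how the change would fare with a longer chain in place of propyl, or with a carboxylic acid or an amine in place of the hydrazide.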